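Longer chain on the shared core: expectation for compound 3

This account rests on a few compounds, and the source may have more. Where it says the series, first, only, none or still open, it means among the compounds named here.

Measured compounds:
- compound 1 `CCCCOC(=O)Nc1ccc([Se]C#N)cc1` gives 14500 nM in an ADME assay on 184B5 cells (Homo sapiens) for cytotoxicity, read by MTT assay, with a stated time of 72 h; on this read-out lower numbers stand for stronger inhibition of growth and higher numbers for weaker inhibition of growth
- compound 2 `C=CCOC(=O)Nc1ccc([Se]C#N)cc1` gives 9800 nM in this assay

Going by the values given here, compound 2 shows the lowest number of the two, but its only neighbour is compound 1, and the step of a 1.5-fold lower number from compound 1 to compound 2 (0.17 log units; within the scatter) lies within the scatter, so the two compounds cannot be put in order on this read-out.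

Compound 3 `CCCCCCOC(=O)Nc1ccc([Se]C#N)cc1` has not yet been measured. It differs from compound 2 by pentyl in place of vinyl on a saturated chain carbon bound to an oxygen next to a carbonyl group. Among the compounds with values here, the one measured step that touches the same place, a 1.5-fold lower number from compound 1 to compound 2 (0.17 log units; within the scatter), swapped one chain for another on that oxygen-bound carbon and stayed within the scatter. Within the data shown here, there is no measured pair in which the chain was lengthened further, so the expectation for the pentyl group rests on that single step alone.

Given this, the change from compound 2 to compound 3 is expected to produce no shift beyond the scatter in this assay, that is a 1.2-fold higher number from compound 2 to compound 3 (0.09 log units; within the scatter). Compound 3 is therefore estimated at 12000 nM, with a range from 5000 nM to 30000 nM.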

Compound 3, concentration for total growth inhibition: 20000 nM
Compound 3: the middle estimate sits 1.7-fold (0.22 log units) below what was measured, and the stated range covers the measured number.
By their numbers in this assay, from the lowest: compounds 2, 1 and 3 (each within the scatter of the next, the first and the last beyond it).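

At this oxygen-bound chain carbon, pentyl in place of vinyl gives the only step among these compounds that clears the scatter in this assay (a 2.0-fold higher number from compound 2 to compound 3 (0.31 log units; beyond the scatter)), so the chain held here can shift the growth-inhibition read-out, though only modestly. Extending the saturated chain alone, with ethyl in place of hydrogen on a saturated chain carbon, four bonds along the chain from an oxygen next to a carbonyl group, stays within the scatter (a 1.4-fold higher number from compound 1 to compound 3 (0.14 log units; within the scatter)), so compound 1 cannot be told apart from either of the others and only compound 2 and compound 3 separate. Nothing available here offers a cause for that separation.

Compound 2 and compound 3 differ in both chain length and the double bond, so this one step cannot show which of the two matters, or whether both do. Also open, as far as these compounds go, is how a chain longer than hexyl, or a chain ending in an amine or a carboxylic acid, would behave at this place.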